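The compounds below may be only part of what the source reports. "The series", "measured", "known", "first", "only" and "open" are said of these compounds alone.

Working notes on the series. In a functional assay on MV4-11 cells (Homo sapiens) for antiproliferative activity, read by CCK-8 assay, with a stated time of 72 h (on this read-out higher numbers stand for weaker inhibition and lower numbers for stronger inhibition), compound 1 `Cn1cc(-c2ccccc2Oc2ccccc2)c2cc(C(=O)NCCCCCCC(=O)NO)[nH]c2c1=O` gives 180 nM, and compound 2 `Cn1cc(-c2cc(C(C)(C)O)ccc2Oc2ccccc2)c2cc(C(=O)NCc3ccc(C(=O)Nc4ccccc4N)cc3)[nH]c2c1=O` gives 100 nM. Among the compounds with values here, these two values lie within the usual scatter of each other, so compound 1 stands level with the only other measured compound. Within the data shown here, the two differ in more than one place, and no measured pair isolates a single change. Compound 3 `Cn1cc(-c2ccccc2Oc2ccccc2)c2cc(C(=O)NCCCCC(=O)NO)[nH]c2c1=O` has not yet been measured. It keeps the core of compound 1 and alters only the chain: hydroxycarbamoyl in place of 2-(hydroxycarbamoyl)ethyl on a saturated chain carbon, four bonds along the chain from an amide-type nitrogen, with hydroxycarbamoyl in place of 2-(hydroxycarbamoyl)ethyl on a saturated chain carbon, four bonds along the chain from an amide-type nitrogen. The data hold no measured chain change, so the expectation rests on the structural change alone. The expected step, toward weaker inhibition and probably beyond the scatter, is a 2.5-fold higher number from compound 1 to compound 3 (0.40 log units; beyond the scatter) in this assay. For compound 3 the estimated value is 450 nM, with an expected range of 170 nM to 1300 nM.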

Compound 3, half-maximal inhibitory concentration: 180 nM
The estimate for compound 3 lay 2.5-fold (0.40 log units) above the measured number; the range from low to high includes it.
By their numbers in this assay, from the lowest: compounds 2, 1 and 3 (each within the scatter of the next).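

In this assay, within the data shown here, the chain change gives no change at the digits printed from compound 1 to compound 3 (within the scatter) as the first measured step at this position, on a saturated chain carbon, four bonds along the chain from an amide-type nitrogen. The same difference, read as 5-(hydroxycarbamoyl)pentyl to 3-(hydroxycarbamoyl)propyl, shows that the number does not respond to this shortening of the chain, so compound 1 and compound 3 stand level with the core of compound 1 unchanged. No measurement bears on why the two chains read alike.

From the compounds shown here alone, whether a shorter chain such as (hydroxycarbamoyl)methyl, or a longer chain such as 6-(hydroxycarbamoyl)hexyl, would also read alike in this assay remains open. Also open, going by these compounds, is what a carboxylic acid in place of the hydroxycarbamoyl end of the chain would give.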